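A few compounds are considered here, and "the series" means these few. Any claim that something is new, unique, unknown or untested is made for them only; others in the source may bear on it.

Of the compounds shown here, three sharing one core have been tested in an ADME assay on NIH3T3 cells (Mus musculus) for cytotoxicity, read by XTT assay, with a stated time of 24 h; a lower number here means a stronger inhibitor, a higher number a weaker inhibitor. Compound 1 `Fc1ccc(/C=N/NC(=S)Nc2cccc3ccccc23)cc1Cl` carries a 3-chloro-4-fluorophenyl group on the carbon with a double bond to nitrogen, and in this assay compound 1 gives 500 ug/mL. Compound 2 `Fc1ccc(/C=N/NC(=S)Nc2cccc3ccccc23)c(F)c1` carries a 2,4-difluorophenyl group in the same place. In this assay compound 2 reaches only the limit > 500 ug/mL, which is a boundary of the measurement and not a number. Compound 3 `Fc1ccc(F)c(/C=N/NC(=S)Nc2cccc3ccccc23)c1` carries a 2,5-difluorophenyl group. For compound 3 this assay likewise reports only the limit > 500 ug/mL. The step of a number no lower from compound 1 to compound 2 (the limit leaves the size open) and the step of a number no lower from compound 1 to compound 3 (the limit leaves the size open) therefore show no lowering, and the step that the two limits leave unreadable from compound 2 to compound 3 cannot be read at all. Compound 4 `Fc1cccc(Cl)c1/C=N/NC(=S)Nc1cccc2ccccc12` differs from compound 3 by 2-chloro-6-fluorophenyl in place of 2,5-difluorophenyl on a carbon with a double bond to nitrogen. Because two of the three values already sit at the limit of > 500 ug/mL in this assay, at which 2 of the 3 values shown sit, nothing in the measured steps points to a change in either direction. The step of a number no higher from compound 3 to compound 4 (the limit leaves the size open) is thus expected to stay within the usual scatter. Compound 4 is estimated at 500 ug/mL, within a range from 250 ug/mL to 500 ug/mL.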

Compound 4, half-maximal inhibitory concentration: > 500 ug/mL
Compound 4 was reported as a limit; the forecaster's own chance of this, stated with the estimate: 65%; the middle value lies on the limit itself.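

In this assay compound 4 gives > 500 ug/mL, which is a limit of the assay and not a number. Among the compounds shown here, on the carbon with a double bond to nitrogen, 2-chloro-6-fluorophenyl thus adds a third group whose result is a limit, and the one step that can be read is a number no lower from compound 1 to compound 4 (the limit leaves the size open), while the steps that join two limits cannot be read. This change therefore adds a direction but no size, and the set now gathers even more at one boundary: the limit of > 500 ug/mL in this assay, at which 3 of the 4 values shown sit.

The compounds shown leave open how far these groups truly differ from one another in this assay. They also leave open whether a phenyl group carrying an amine or a carboxylic acid in this place would give a result that can be read as a number.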